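A few compounds are considered here, and "the series" means these few. Any claim that something is new, unique, unknown or untested is made for them only; others in the source may bear on it.

Three compounds built on a shared core were examined in a functional assay on JAR cells (Homo sapiens) for inhibition, read by MTT assay, with a stated time of 72 h, tested at 10 uM; a lower number here means less inhibition, a higher number more inhibition at the concentration tested (going by the name of the read-out). Compound 1 `CCOC(=O)C1=C(Nc2ccccc2)S/C(=C\c2ccc(O)c(O)c2)C1=O` gives 48.7% in this assay. Compound 2 `CCOC(=O)C1=C(Nc2ccccc2)S/C(=C\c2cc(OC)ccc2OC)C1=O` gives 38.1%, and compound 3 `CCOC(=O)C1=C(Nc2ccccc2)S/C(=C\c2cc(OC)c(O)c(OC)c2)C1=O` gives 57.5%. Among these three numbers compound 1 stands second highest: its value and that of compound 3 lie within the usual scatter of each other, whereas the gap from compound 1 down to compound 2 lies beyond it.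

The untested compound 4 `CCOC(=O)C1=C(Nc2ccccc2)S/C(=C\c2ccc[nH]2)C1=O` differs from compound 1 in one place: 1H-pyrrol-2-yl in place of 3,4-dihydroxyphenyl on a double-bonded chain carbon bound to a double-bonded ring carbon. Among the measured compounds shown here, no pair of measured compounds shows this change, so its effect cannot be read from the numbers at hand. A step down, estimated at a number 12.7 percentage points lower from compound 1 to compound 4 (beyond the scatter), is expected, and it may reach only to the edge of the scatter. The estimate for compound 4 is 36%, with a range from 15% to 55%.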

Compound 4, a percentage reported as inhibition, at one concentration (the size of the read-out at that concentration, not a potency): 49.2%
Compound 4: the middle estimate sits 13.2 percentage points below what was measured; the range from low to high includes it.
By their numbers in this assay, from the lowest: compound 2; then compounds 1, 4 and 3 (each within the scatter of the next).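

In this assay, among the compounds shown here, the exchange of 3,4-dihydroxyphenyl for 1H-pyrrol-2-yl gives a number 0.5 percentage points higher from compound 1 to compound 4 (within the scatter) and is the first step here that can be read at this place, on a double-bonded chain carbon bound to a double-bonded ring carbon. The earlier compounds shown here all carried substituted six-membered aromatic rings of carbon only, so they could not show that a smaller five-membered aromatic ring with one hetero atom leaves the inhibition at the tested concentration within the scatter of compound 1. Nothing at hand explains why these two groups read alike.

On these data alone, it remains open whether an amine, a carboxylic acid or a longer chain at this place would keep the number. Also open, as far as these compounds go, is whether a furan-2-yl or a pyridin-2-yl ring would read like 1H-pyrrol-2-yl.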